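The compounds below may be only part of what the source reports. "The series", "measured", "known", "first", "only" and "open" are said of these compounds alone.

Working notes on the series built on the shared core of compound 1 `COC1=C(C)C(=O)/C(=C(O)/C=C/c2ccc(OC)cc2)C(=O)C1(C)C`. In a functional assay on KB cells (Homo sapiens) for cytotoxicity (a lower number here means that less compound is needed, a higher number that more compound is needed for the effect), compound 1 gives 3.6 ug/mL, compound 2 `COC1=C(C)C(=O)/C(=C(O)/C=C/c2ccc(F)cc2)C(=O)C1(C)C` gives 3.7 ug/mL, and compound 3 `COC1=C(C)C(=O)/C(=C(O)/C=C/c2ccccc2C)C(=O)C1(C)C` gives 4.1 ug/mL. Compound 3 cannot be separated from the other two on these numbers, with a 1.1-fold higher number from compound 1 to compound 3 (0.06 log units; within the scatter) and a 1.1-fold higher number from compound 2 to compound 3 (0.04 log units; within the scatter).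

Compound 4 `COC1=C(C)C(=O)/C(=C(O)/C=C/c2c(C)cccc2C)C(=O)C1(C)C` is the next member, and its change from compound 3 is methyl in place of hydrogen on an aromatic carbon. In words, this is methyl in place of hydrogen on an aromatic carbon, taking 2-methylphenyl to 2,6-dimethylphenyl.

Among the measured compounds shown here, no measured step makes this exact change. The closest evidence comes from the other changes on the same aromatic ring: a 1.0-fold higher number from compound 1 to compound 2 (0.01 log units; within the scatter) for fluoro in place of methoxy, and a 1.1-fold higher number from compound 1 to compound 3 (0.06 log units; within the scatter) for 2-methylphenyl in place of 4-methoxyphenyl. Both steps stay within the scatter, and none of the three measured compounds goes against this flat picture, though three compounds are a thin basis. No step beyond the scatter is therefore expected in this assay, and no direction is favoured. The expected step is a 1.0-fold lower number from compound 3 to compound 4 (0.01 log units; within the scatter). For compound 4 the estimated value is 4 ug/mL, with an expected range of 2.2 ug/mL to 7.5 ug/mL.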

Compound 4, concentration for half-maximal effect: 7.1 ug/mL
Compound 4: middle estimate off by 1.8-fold (0.25 log units), on the low side; measured number inside the range.
By their numbers in this assay, from the lowest: compounds 1, 2, 3 and 4 (each within the scatter of the next).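

Among the compounds shown here, the methyl in place of hydrogen, ortho to a large group and meta to a methyl group, gives the first reading of a single-atom addition on this ring: in this assay it yields a 1.7-fold higher number from compound 3 to compound 4 (0.24 log units; within the scatter) and so does not separate 2,6-dimethylphenyl from 2-methylphenyl. For the compounds shown here, the exchanges of the whole aryl group on the double-bonded chain carbon give a 1.9-fold higher number from compound 2 to compound 4 (0.28 log units; within the scatter) and a 2.0-fold higher number from compound 1 to compound 4 (0.29 log units; within the scatter) and also stay inside the scatter, so the flat picture now extends to a ring with two methyl groups, with no compound among the four going against it. Nothing measured here speaks to the reason for the size of these steps.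

The ring substituents shown are only methyl, methoxy and fluoro, so it remains open whether an amine, a hydroxyl or a carboxylic acid on this ring would give a step beyond the scatter. The shared core is also the same in all four compounds, which leaves open how a longer chain between the core and the ring would read in this assay as well.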